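Removing an Amino Group: Expected Effect on Cell Growth Inhibition

The compounds below may be only part of what the source reports. "The series", "measured", "known", "first", "only" and "open" are said of these compounds alone.

compound 1 `Nc1nc(Cl)c2ncn(Cc3ccccc3CCl)c2n1` — 44700 nM
compound 2 `ClCc1ccccc1Cn1cnc2nc(Cl)nc(Cl)c21` — "not determined" (no result reported)
compound 3 `Nc1nc(Cl)c2ncn(Cc3cccc(CCl)c3)c2n1` — 32400 nM

In a functional assay on UO-31 cells (Homo sapiens) for cytotoxicity, read by sulforhodamine B assay, with a stated time of 48 h (a lower number here means a stronger inhibitor of growth, a higher number a weaker inhibitor of growth), compound 1 gives 44700 nM, which is the higher of the two numbers recorded. Its closest neighbour is compound 3, whose value of 32400 nM differs from that of compound 1 by less than the usual scatter, so the two cannot be told apart on these data. For compound 2 the result in this assay is "not determined" (no result reported).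

Compound 4 `ClCc1ccccc1Cn1cnc2c(Cl)ncnc21` has not been measured. It differs from compound 1 in one place: hydrogen in place of amino on an aromatic carbon. Among the measured compounds shown here, no pair of measured compounds shows such a change, so the size of the step cannot be read from the data. Because compound 1 gives 44700 nM and compound 3 gives 32400 nM, both in a narrow band of weak growth inhibition, compound 4 is expected to remain in the same region. For compound 4 the expected step is a 1.3-fold higher number from compound 1 to compound 4 (0.13 log units; within the scatter), most likely toward a slightly higher number but not beyond the scatter with confidence. In this assay compound 4 is therefore estimated at 60000 nM, with a range from 20000 nM to 180000 nM.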

Compound 4, concentration for total growth inhibition: 10500 nM
The estimate for compound 4 lay 5.7-fold (0.76 log units) above the measured number; measured number below the stated range.
By their numbers in this assay, from the lowest: compound 4; then compounds 3 and 1 (each within the scatter of the next).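

In this assay, the amino group on the aromatic carbon between two ring nitrogen atoms proves dispensable for growth inhibition: putting hydrogen in its place gives a 4.3-fold lower number from compound 1 to compound 4 (0.63 log units; beyond the scatter), a modest step but one beyond the scatter. Compounds 1 and 3 both carry this amino group and lie within the scatter of each other, so they gave no reading of this position, whereas the present pair shows that the number does respond to a change there, and that it moves toward stronger inhibition of growth when the amino group leaves. The data shown offer nothing that accounts for the size or direction of this step.

From the compounds shown here alone, it remains open whether a methyl group, a methoxy group or a dimethylamino group on this same carbon would lie closer to compound 1 or to compound 4, and so whether hydrogen itself matters or only the loss of amino. Going by these compounds, it is equally open whether the same replacement would give a step of similar size on compound 3, where the chloromethyl group sits elsewhere on the benzene ring.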